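Shifting the acyl group on the exocyclic alkene

A few compounds are considered here, and "the series" means these few. Any claim that something is new, unique, unknown or untested is made for them only; others in the source may bear on it.

Of the compounds shown here, three sharing one core have been tested in a functional assay on HT-1080 cells (Homo sapiens) for cytotoxicity, read by MTT assay, with a stated time of 48 h; on this read-out lower numbers stand for stronger inhibition and higher numbers for weaker inhibition. Compound 1 `CC1(C)S[C@@H]2/C(=C\C(=O)c3ccco3)C(=O)N2[C@H]1C(=O)OC(c1ccccc1)c1ccccc1` gives 45500 nM, compound 2 `CCOC(=O)/C=C1/C(=O)N2[C@@H]1SC(C)(C)[C@@H]2C(=O)OC(c1ccccc1)c1ccccc1` gives 25100 nM, and compound 3 `CC1(C)S[C@@H]2/C(=C\C(=O)c3ccc(F)cc3)C(=O)N2[C@H]1C(=O)OC(c1ccccc1)c1ccccc1` gives 11200 nM. On these numbers compound 3 stands lowest; the step of a 4.1-fold lower number from compound 1 to compound 3 (0.61 log units; beyond the scatter) was modest, as was a 2.2-fold lower number from compound 2 to compound 3 (0.35 log units; beyond the scatter), while a 1.8-fold lower number from compound 1 to compound 2 (0.26 log units; within the scatter) stayed within the scatter.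

Compound 4 `CC1(C)S[C@@H]2/C(=C\C(=O)OCc3ccccc3)C(=O)N2[C@H]1C(=O)OC(c1ccccc1)c1ccccc1` differs from compound 3 by benzyloxy in place of 4-fluorophenyl on a carbonyl carbon. The step that bears most directly on this change is a 2.2-fold lower number from compound 2 to compound 3 (0.35 log units; beyond the scatter), where an ester on that carbonyl carbon gave the higher number and the 4-fluorophenyl ketone the lower. Compound 4 returns to an ester, now with a benzyloxy group, for which no measured comparison exists. A modest rise is therefore expected, and the estimated step of a 1.8-fold higher number from compound 3 to compound 4 (0.25 log units; within the scatter) reflects this. Compound 4 is estimated at 20000 nM, with a range from 9000 nM to 45000 nM in this assay.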

Compound 4, half-maximal inhibitory concentration: 11700 nM
Compound 4: middle estimate off by 1.7-fold (0.23 log units), on the high side; measured number inside the range.
By their numbers in this assay, from the lowest: compounds 3 and 4 (each within the scatter of the next); then compounds 2 and 1 (each within the scatter of the next).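

In this assay, the step (a 1.0-fold higher number from compound 3 to compound 4 (0.02 log units; within the scatter)) shows that on this carbonyl carbon an ester need not give a higher number than a ketone: benzyloxy and 4-fluorophenyl cannot be told apart here. Among the esters, the step (a 2.1-fold lower number from compound 2 to compound 4 (0.33 log units; beyond the scatter)) shows that phenyl in place of methyl on the saturated chain carbon bound to an oxygen changes the number beyond the scatter, and the step (a 3.9-fold lower number from compound 1 to compound 4 (0.59 log units; beyond the scatter)) places benzyloxy, like 4-fluorophenyl, clearly apart from furan-2-yl. No measurement shown here accounts for these steps.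

The compounds shown leave open how a longer phenethyloxy chain or a benzylamine-derived amide would read on this carbonyl carbon. They also leave open whether a fluorine on the benzyloxy ring would shift the number.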